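The source may report more compounds than this note shows. Statements on the series, on what has been measured and on what is new or still open speak of the compounds shown alone.

Measured compounds:
compound 1, `Cn1c(=O)c(S(=O)(=O)c2ccc(F)cc2[N+](=O)[O-])cc2cnc(Nc3ccc4[nH]ccc4c3)nc21`, 1500 nM
compound 2, `Cn1c(=O)c(S(=O)(=O)Cc2ccc(F)cc2)cc2cnc(Nc3ccc4[nH]ccc4c3)nc21`, 30000 nM
compound 3, `Cn1c(=O)c(S(=O)(=O)c2ccc(Br)cc2)cc2cnc(Nc3ccc4[nH]ccc4c3)nc21`, 5000 nM

All three were tested in a functional assay on DU-145 cells (Homo sapiens) for inhibition, read by trypan blue exclusion, with a stated time of 72 h; a lower number here means a stronger inhibitor, a higher number a weaker inhibitor. Compound 3 gives the second highest of the three numbers. Its nearest neighbour is compound 1: the step is a 3.3-fold higher number from compound 1 to compound 3 (0.52 log units; beyond the scatter). Its furthest neighbour is compound 2: the step is a 6.0-fold lower number from compound 2 to compound 3 (0.78 log units; beyond the scatter).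

Compound 4, `Cn1c(=O)c(S(=O)(=O)c2ccc(N)cc2F)cc2cnc(Nc3ccc4[nH]ccc4c3)nc21`, has not yet been measured. It differs from compound 3 in one place: 4-amino-2-fluorophenyl in place of 4-bromophenyl on a sulfonyl sulfur.

Within the data shown here, two measured steps bear on this. The step of a 3.3-fold higher number from compound 1 to compound 3 (0.52 log units; beyond the scatter) exchanges one substituted phenyl on the sulfonyl sulfur for another, and is modest. The step of a 20-fold higher number from compound 1 to compound 2 (1.30 log units; beyond the scatter), which puts a 4-fluorobenzyl in place of a phenyl directly on the sulfur, is large. The change to compound 4 keeps a six-membered aromatic ring of carbon only on the sulfonyl sulfur and alters only what is on that ring, so it is of the first kind. A modest step is therefore expected for compound 4, and, since the only other substituted phenyl, on compound 1, gave a lower number than compound 3, the expected direction is toward a lower number: a 2.0-fold lower number from compound 3 to compound 4 (0.30 log units; within the scatter).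

Compound 4 is estimated to give 2500 nM, within a range from 800 nM to 8000 nM.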

Compound 4, half-maximal inhibitory concentration: 8000 nM
Compound 4: the middle estimate sits 3.2-fold (0.51 log units) below what was measured, within the range that was stated.
By their numbers in this assay, from the lowest: compound 1; then compounds 3 and 4 (each within the scatter of the next); then compound 2.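

In this assay, the exchange of 4-bromophenyl for 4-amino-2-fluorophenyl on the sulfonyl sulfur gives a 1.6-fold higher number from compound 3 to compound 4 (0.20 log units; within the scatter) and so does not separate these two substituted phenyl groups, even though the entering group carries a hydrogen-bond donor and acceptor that the leaving group lacks. The other two steps place the new group clearly apart from both earlier extremes, with a 5.3-fold higher number from compound 1 to compound 4 (0.73 log units; beyond the scatter) from the 4-fluoro-2-nitrophenyl group and a 3.8-fold lower number from compound 2 to compound 4 (0.57 log units; beyond the scatter) from the 4-fluorobenzyl group, so a directly attached substituted phenyl does not by itself match compound 1, while compound 2 remains the weakest of the four and compound 1 the strongest. Nothing shown gives a reason for these differences.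

No pair shown separates the nitro group of compound 1 from its fluorine, or the amine of compound 4 from its fluorine, so it remains open which of these groups matters. As far as these compounds go, it also remains open whether a plain phenyl, or a phenyl bearing a methoxy group or a carboxylic acid, on the sulfonyl sulfur would fall with compound 1 or with compound 3 and compound 4.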